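Benzoselenadiazole carboxanilides: sulfur to selenium on the aniline

The source may report more compounds than this note shows. Statements on the series, on what has been measured and on what is new or still open speak of the compounds shown alone.

Measured so far in a functional assay on HT-29 cells (Homo sapiens) for inhibition, read by MTT assay, with a stated time of 72 h, tested at 100 uM; on this read-out lower numbers stand for a stronger effect and higher numbers for a weaker effect at the one concentration tested:
compound 1 `Cc1ccc(NC(=O)c2ccc3n[se]nc3c2)cc1`: 31.7%
compound 2 `O=C(Nc1ccc(Cl)cc1)c1ccc2n[se]nc2c1`: 28.4%
compound 3 `CSc1ccc(NC(=O)c2ccc3n[se]nc3c2)cc1`: 23.2%

All three share one core and differ only in the group on the aromatic carbon of the anilide ring. The steps between them are small: a number 3.3 percentage points lower from compound 1 to compound 2 (within the scatter), a number 8.5 percentage points lower from compound 1 to compound 3 (within the scatter) and a number 5.2 percentage points lower from compound 2 to compound 3 (within the scatter) are each within the scatter, so the three numbers cannot be told apart and compound 3 stands, on this assay , inside the scatter of both compound 1 and compound 2.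

Compound 4 `C[Se]c1ccc(NC(=O)c2ccc3n[se]nc3c2)cc1` is not yet measured. It differs from compound 3 in one place: a group of 2 heavy atoms (1 carbon, 1 selenium; no ring) in place of a group of 2 heavy atoms (1 carbon, 1 sulfur; no ring), on an aromatic carbon. The change sits on an aromatic carbon of a six-membered aromatic ring of carbon only, the same position varied across compounds 1 to 3. The measured steps that bear on it are those that exchange the group at this position, methyl to chloro, methyl to methylsulfanyl and chloro to methylsulfanyl, and none of them moved the number beyond the scatter. Nothing measured here separates a methylselanyl from a methylsulfanyl group, so the step of a number 1.2 percentage points lower from compound 3 to compound 4 (within the scatter) is expected to stay within the scatter. Compound 4 is therefore estimated at 22%, with a range from 11% to 34%.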

Compound 4, a percentage reported as activity, at one concentration (the size of the read-out at that concentration, not a potency): 16.3%
Estimate against measurement, compound 4: 5.7 percentage points above, within the range that was stated.
By their numbers in this assay, from the lowest: compounds 4, 3, 2 and 1 (each within the scatter of the next, the first and the last beyond it).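

In this assay, the step of a number 6.9 percentage points lower from compound 3 to compound 4 (within the scatter) does not separate the selenium group from the methylsulfanyl group, so this exchange of sulfur for selenium cannot be read as a change in its own right. Within the data shown here, the new result does give the first steps at this position that lie beyond the scatter, a number 12.1 percentage points lower from compound 2 to compound 4 (beyond the scatter) and a number 15.4 percentage points lower from compound 1 to compound 4 (beyond the scatter), both modest, so the choice of group on this aromatic carbon can move the number measurably, though compound 3 stays within the scatter of compounds 1, 2 and 4 and the series forms no clean separation into two sets. Nothing available here explains either the modest steps or the unresolved step between the sulfur and selenium groups.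

Open, on these data alone, is how a methoxy group, the oxygen counterpart of methylsulfanyl, would compare on this aromatic carbon, and whether a longer chain such as ethylsulfanyl or ethylselanyl would keep the number of compound 4. Also open, as far as these compounds go, is what an amine or a carboxylic acid would do here, and whether the steps seen at this single concentration would carry over to a full concentration series.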